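This account rests on a few compounds, and the source may have more. Where it says the series, first, only, none or still open, it means among the compounds named here.

Measured in a physicochemical assay for solubility, read by HPLC, using the shake flask method, measured as kinetic solubility, with a stated time of 20 h, at pH 6.5, tested at 200 uM (on this read-out lower numbers stand for lower solubility and higher numbers for higher solubility), so far:
compound 1 `C[C@@H](CO)NS(=O)(=O)c1cccc(-c2ccc3nccc(-c4ccncc4)c3n2)c1` gives 50000 nM
compound 2 `CS(=O)(=O)c1cccc(-c2ccc3nccc(N4CCNCC4)c3n2)c1` gives 165000 nM
compound 3 `O=S(=O)(c1cccc(Nc2ccc3nccc(-c4ccncc4)c3n2)c1)N1CCCCC1` gives 15000 nM

Compound 1 stands in the middle of these three numbers. Compound 2 reads higher and compound 3 reads lower, and both gaps from compound 1 lie beyond the usual scatter.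

The next compound to be tested is compound 4 `O=S(=O)(c1cccc(-c2ccc3nccc(-c4ccncc4)c3n2)c1)N1CCC(O)CC1`. It keeps the core of compound 1 and carries 4-hydroxypiperidin-1-yl in place of (1-(hydroxymethyl)ethyl)amino on a sulfonyl sulfur. Read one bond further out, a (1-(hydroxymethyl)ethyl)sulfamoyl group becomes a (4-hydroxypiperidin-1-yl)sulfonyl group.

Going by the values given here, no two measured compounds differ in one place only, so the data hold no direct precedent for this change. Among the compounds with values here, the nearest hint is weak: compound 3, the only measured compound with a ring on its sulfonyl sulfur, reads 15000 nM, but it also differs from compound 1 elsewhere. The step expected is a 1.8-fold lower number from compound 1 to compound 4 (0.25 log units; within the scatter), small and downward, about the size of the usual scatter. For compound 4 the estimated value is 28000 nM, with an expected range from 9000 nM to 80000 nM.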

Compound 4, solubility: 10000 nM
Compound 4: middle estimate off by 2.8-fold (0.45 log units), on the high side; the range from low to high includes it.
By their numbers in this assay, from the lowest: compounds 4 and 3 (each within the scatter of the next); then compound 1; then compound 2.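

In this assay, going by these compounds alone, the sulfonyl sulfur on the core of compound 1 proves to be a place where the choice of group shows in the read-out: putting 4-hydroxypiperidin-1-yl in place of (1-(hydroxymethyl)ethyl)amino gives a 5.0-fold lower number from compound 1 to compound 4 (0.70 log units; beyond the scatter), the first single change in this set that can be read directly, and one that lies beyond the scatter. The hydroxyl is present on both sides of the change, so its presence alone does not carry the number of compound 1 over to compound 4. No supporting measurement accompanies this result, so the step stands without any explanation from the data.

This one step changes several things together, swapping an open chain with a defined stereocentre and 2 hydrogen-bond donors for a six-membered non-aromatic ring with 1 hydrogen-bond donor, and it cannot show which of these differences matters. It also leaves open how the same core would read with a different group on the sulfonyl sulfur, such as a morpholine ring, a piperazine ring or a side chain ending in a carboxylic acid.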